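The source may report more compounds than this note shows. Statements on the series, on what has been measured and on what is new or still open speak of the compounds shown alone.

Working notes on the series.

Within the data shown here, compound 1 `CN(C)CCCn1nc(C2=C(c3cn(C)c4ccccc34)C(=O)NC2=O)c2cccnc21` is the first member; in a functional assay on A549 cells (Homo sapiens) for antiproliferative activity, read by MTT assay, with a stated time of 48 h (on this read-out lower numbers stand for stronger inhibition and higher numbers for weaker inhibition), compound 1 gives only a limit, > 100000 nM. Compound 3 `Cn1cc(C2=C(c3nn(CCCn4ccnc4)c4ncccc34)C(=O)NC2=O)c2ccccc21` differs from compound 1 only in carrying 1H-imidazol-1-yl in place of dimethylamino on a saturated chain carbon; in this assay compound 3 likewise gives only a limit, > 100000 nM. The step that the two limits leave unreadable from compound 1 to compound 3 therefore cannot be read, and it touches the chain, not the imide nitrogen. Among the measured compounds shown here, compound 2 `COc1ccc(N2C(=O)C(c3cn(C)c4ccccc34)=C(c3nn(CCCN4CCCCC4)c4ncccc34)C2=O)cc1` is the one member with a number: in this assay compound 2 gives 30300 nM. It thus stands alone below the limit, since (the limit of > 100000 nM in this assay, at which 2 of the 3 values shown sit).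

Compound 4 `Cn1cc(C2=C(c3nn(CCCN4CCCCC4)c4ncccc34)C(=O)N(c3ccccc3)C2=O)c2ccccc21` is not yet measured. It differs from compound 2 by hydrogen in place of methoxy on an aromatic carbon; cut one bond further out, the change reads 4-methoxyphenyl to phenyl. For the measured compounds named here, no measured pair alters this position, so no step bears directly on it; the only readable comparison in the set is the unreadable one between compound 1 and compound 3 at a different place. With no evidence for a shift either way, the change from compound 2 is expected to stay within the scatter, as a 1.2-fold higher number from compound 2 to compound 4 (0.06 log units; within the scatter). Compound 4 is therefore estimated at 35000 nM in this assay, with a range from 10000 nM to 100000 nM.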

Compound 4, half-maximal inhibitory concentration: 20600 nM
Estimate against measurement, compound 4: 1.7-fold (0.23 log units) above; measured number inside the range.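

Working from the one readable pair, in this assay the change from 4-methoxyphenyl to phenyl gives a 1.5-fold lower number from compound 2 to compound 4 (0.17 log units; within the scatter), so hydrogen in place of methoxy on this aromatic carbon, para to a large group, leaves the two compounds indistinguishable in this read-out. The earlier compounds shown here gave no view of this position, and compound 4 now shows that a measured number, rather than a limit, does not require the methoxy group here. The other two members differ from this pair in more than one place and give no number to set beside it: the limit of > 100000 nM in this assay, at which 2 of the 4 values shown sit.

Open, from the compounds shown here alone, is whether a different group on this same carbon, such as fluorine, an amine or a carboxylic acid, would move the number beyond the usual scatter of this read-out. Also open, going by these compounds, is what hydrogen on the imide nitrogen would give with the chain of compound 4 held unchanged, and what a longer chain would give with the phenyl group kept in place.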